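A few compounds are considered here, and "the series" means these few. Any claim that something is new, unique, unknown or untested is made for them only; others in the source may bear on it.

Of the compounds shown here, two have been tested so far in a functional assay on the whole organism (Ear) for inhibition, with Mus musculus as the target, at a dose of 40 mg/kg by the oral route; a lower number here means less inhibition, a higher number more inhibition at the dose given (going by the name of the read-out). Compound 1, `O=C(Oc1ccc(-c2ccc(F)cc2F)cc1C(=O)O)c1ccccc1`, gives 16.1%. Compound 2, `O=C(Oc1ccc(-c2ccc(F)cc2F)cc1C(=O)Nc1ccccc1)c1ccccc1`, gives 19.8%. Among the compounds with values here, the single step between them, anilino in place of hydroxy on a carbonyl carbon, moved the read-out by a number 3.7 percentage points higher from compound 1 to compound 2 (within the scatter), so the two numbers lie within the scatter of each other and the inhibition in this assay is level between them.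

Compound 3, `Cc1ccccc1NC(=O)c1cc(-c2ccc(F)cc2F)ccc1OC(=O)c1ccccc1`, is the next candidate. It differs from compound 2 by methyl in place of hydrogen on an aromatic carbon, that is, phenylcarbamoyl to (2-methylphenyl)carbamoyl. Within the data shown here, no measured step touches that aromatic ring; the only step known, from compound 1 to compound 2, changed the carbonyl substituent and lay within the scatter. There is therefore no basis for expecting a shift beyond the scatter in this assay. Compound 3 is expected to give about 20%, a step of a number 0.2 percentage points higher from compound 2 to compound 3 (within the scatter), with a likely range of 8% to 34%.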

Compound 3, a percentage reported as inhibition, in the whole organism at one dose (the size of the read-out at that dose, not a potency): 21.4%
For compound 3 the middle estimate is 1.4 percentage points below the measured one; the measured number falls inside the stated range.
By their numbers in this assay, from the lowest: compounds 1, 2 and 3 (each within the scatter of the next).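

Within the data shown here, this is the first look at the aromatic ring of the phenylcarbamoyl group: in this assay, the change to (2-methylphenyl)carbamoyl, which puts a methyl ortho to a large group, moves the read-out by a number 1.6 percentage points higher from compound 2 to compound 3 (within the scatter) and leaves the inhibition level. Putting (2-methylphenyl)amino in place of hydroxy on the carbonyl carbon moves it by a number 5.3 percentage points higher from compound 1 to compound 3 (within the scatter) and so, even with both changes taken together, the numbers stay level. Nothing at hand offers an explanation for these results.

As far as these compounds go, it remains open whether a methoxy group, a longer chain such as propyl, an amine or a carboxylic acid on this ring would move the number beyond the scatter. From the compounds shown here alone, with every number taken at a single dose, how these compounds compare at other doses also stays open.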